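Swapping the aryl group on the amine of compound 1

The compounds below may be only part of what the source reports. "The series", "measured", "known", "first", "only" and "open" are said of these compounds alone.

Measured so far:
compound 1, `O=C1C=C(Nc2ccc(C(F)(F)F)cc2)C(=O)c2c1nc1n2[C@H]2OC[C@@H](O)[C@H]2OC1`: 2820 nM
compound 3, `O=C1C(Nc2ccc(C(F)(F)F)cc2)=CC(=O)c2c1nc1n2[C@H]2OC[C@@H](O)[C@H]2OC1`: 1860 nM
compound 2, `O=C1C(N2CCCC2)=CC(=O)c2c1nc1n2[C@H]2OC[C@@H](O)[C@H]2OC1`: > 16000 nM

Of the compounds shown here, three sharing one core have been tested in a functional assay on MGC-803 cells (Homo sapiens) for inhibition, read by sulforhodamine B assay; on this read-out higher numbers stand for weaker inhibition and lower numbers for stronger inhibition. Compound 1 has the highest of the two numbers recorded; compound 3 sits close by, and the gap between them stays within the scatter, so the two cannot be told apart. For compound 2 the assay returned only a limit, (the limit of > 16000 nM in this assay, at which 1 of the 3 values shown sits), and not a number.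

Compound 4, `COc1ccccc1NC1=CC(=O)c2nc3n(c2C1=O)[C@H]1OC[C@@H](O)[C@H]1OC3`, has not yet been measured. It is built from compound 1 by a single change: 2-methoxyphenyl in place of 4-(trifluoromethyl)phenyl on an amine nitrogen. Within the data shown here, no step between two measured compounds mirrors this change, so its effect is unknown. The expectation is for a step in this assay of modest size at most, in either direction, most likely not beyond the scatter. Compound 4 is therefore expected to give about 3000 nM, somewhere between 1000 nM and 10000 nM, which means an estimated step of a 1.1-fold higher number from compound 1 to compound 4 (0.03 log units; within the scatter).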

Compound 4, half-maximal inhibitory concentration: 1630 nM
Beside the measured number, compound 4's estimate is 1.8-fold (0.26 log units) above it; the range from low to high includes it.
By their numbers in this assay, from the lowest: compounds 4, 3 and 1 (each within the scatter of the next). At a limit, above all of these: compound 2.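

Replacing 4-(trifluoromethyl)phenyl with 2-methoxyphenyl on the amine nitrogen gives, in this assay, a 1.7-fold lower number from compound 1 to compound 4 (0.24 log units; within the scatter). Among these compounds, this is the first step read at this place, and it shows that two aryl groups with different atoms, one carrying fluorine and the other oxygen, cannot be told apart here. Nothing shown bears on why the two groups read alike.

From the compounds shown here alone, whether the same holds for a plain phenyl, a benzyl group or an aryl ring carrying a carboxylic acid remains open. Also open, going by these compounds, is whether 2-methoxyphenyl would read the same on the core of compound 3, which carries 4-(trifluoromethyl)phenyl on its amine nitrogen.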